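The source may hold more compounds than are shown below. What is called first, only, known or untested is meant among the compounds shown, and "the series" means these compounds.

Measured compounds in a functional assay on OCI-AML2 cells (Homo sapiens) for antiproliferative activity, read by WST assay, with a stated time of 3 days; on this read-out higher numbers stand for weaker inhibition and lower numbers for stronger inhibition:
compound 1 `[N-]=[N+]=Nc1cc(=O)[nH]c(=O)n1[C@@H]1O[C@H](CO)[C@@H](O)[C@H]1O` — > 50000 nM, a limit of the assay.
compound 2 `CNc1cc(=O)[nH]c(=O)n1[C@@H]1O[C@H](CO)[C@@H](O)[C@H]1O` — > 50000 nM, also a limit.

For the measured compounds named here, compound 1 thus stands only at the limit, as does the one other value shown, so the limit of > 50000 nM in this assay, at which 2 of the 2 values shown sit, is the whole of the evidence. Going by the values given here, the single measured step, a step that the two limits leave unreadable from compound 1 to compound 2, is not readable between these limits. Compound 3 `[N-]=[N+]=Nc1c(F)c(=O)[nH]c(=O)n1[C@@H]1O[C@H](CO)[C@@H](O)[C@H]1O` differs from compound 1 by fluoro in place of hydrogen on an aromatic carbon. No measured step bears on that change, and nothing shown gives a reason to expect a step in this assay beyond the scatter. Compound 3 is therefore expected at 50000 nM (range 10000 nM to 200000 nM), most likely again reported as a limit, the step of a number no higher from compound 1 to compound 3 (the limit leaves the size open) being an estimate only.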

Compound 3, half-maximal inhibitory concentration: 700 nM
Compound 3: middle estimate off by 71-fold (1.85 log units), on the high side; the measured number lies below the stated range.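

In this assay, fluoro in place of hydrogen on an aromatic carbon, ortho to an azido group, gives an at least 71-fold lower number from compound 1 to compound 3 (1.85 log units; beyond the scatter), so this single atom change moves the read-out by more than the scatter. The earlier pair could not show this, since the step between compound 1 and compound 2 cannot be read. Compound 3 is the only compound shown with a value clear of the limit: the limit of > 50000 nM in this assay, at which 2 of the 3 values shown sit.

Open, from the compounds shown here alone, is whether chloro or methyl at this position gives a similar step. Also open, going by these compounds, is whether the step depends on the azido group, which an amine in its place on compound 3 would test.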